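The compounds below may be only part of what the source reports. "The series", "measured", "known", "first", "only" and "open" are said of these compounds alone.

Measured so far in a functional assay on OVCAR-3 cells (Homo sapiens) for antiproliferative activity, read by sulforhodamine B assay, with a stated time of 72 h; a higher number here means a weaker inhibitor, a lower number a stronger inhibitor:
compound 1 `O=C1CS/C(=N/Nc2nncc3ccccc23)N1c1ccccc1` gives 44 nM
compound 2 `C(=C/c1ccccc1)\C(=N\Nc1nncc2ccccc12)c1ccccc1` gives 3.3 nM
compound 3 `Clc1ccc(C(/C=C/c2ccccc2)=N\Nc2nncc3ccccc23)cc1` gives 5.4 nM

Compound 1 (44 nM) holds the highest number of the three. Compound 3 (5.4 nM) and compound 2 (3.3 nM) both lie lower by more than the scatter.

Next is compound 4 `O=C1CS/C(=N/Nc2nncc3ccccc23)N1`, which keeps the core of compound 1 but has hydrogen in place of phenyl on an amide-type nitrogen in a ring. Among the measured compounds shown here, only one measured step is available, a 1.6-fold higher number from compound 2 to compound 3 (0.21 log units; within the scatter), and it is chloro in place of hydrogen on an aromatic carbon. That step lies within the scatter, but it is a different kind of change and does not involve the core of compound 1. It therefore bears only weakly on the loss of a whole phenyl. For the measured compounds named here, no measured pair shows that loss, so both size and direction remain open. A moderate move toward a higher number in this assay is expected, perhaps just beyond the scatter. The estimated change is a 2.7-fold higher number from compound 1 to compound 4 (0.44 log units; beyond the scatter). For compound 4 the expected value is 120 nM, with an estimated range from 25 nM to 450 nM.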

Compound 4, half-maximal inhibitory concentration: 46 nM
Compound 4: middle estimate off by 2.6-fold (0.42 log units), on the high side; low and high end bracket the measured number.
By their numbers in this assay, from the lowest: compounds 2 and 3 (each within the scatter of the next); then compounds 1 and 4 (each within the scatter of the next).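

Replacing phenyl with hydrogen on an amide-type nitrogen in a ring gives a 1.0-fold higher number from compound 1 to compound 4 (0.02 log units; within the scatter) in this assay. Among the compounds shown here, this is the first reading of that change, and it shows that, on the core of compound 1, the whole phenyl can leave this position, two ring bonds from the ring sulfur, without a shift in the number beyond the scatter. No measured information available here accounts for this result, so no cause can be assigned to it.

Only phenyl and hydrogen are shown on this nitrogen, so it remains open whether a methyl, a benzyl, a longer alkyl chain or a phenyl bearing chloro would leave the number within the scatter of compound 1 and compound 4 or move it in either direction. Going by these compounds, it also remains open whether the same change would read alike on a core other than that of compound 1, since this single pair speaks for this core alone.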